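Cyclohexyl Swapped for a Dibromobutenyl Chain

A few compounds are considered here, and "the series" means these few. Any claim that something is new, unique, unknown or untested is made for them only; others in the source may bear on it.

Compound 1 `C[C@H]1CC(Cl)=C([Si](C)(C)C)[C@@H](C2CCCCC2)O1` gives 32000 nM in a functional assay on A2780 cells (Homo sapiens) for antiproliferative activity; on this read-out lower numbers stand for stronger inhibition of growth and higher numbers for weaker inhibition of growth.
Compound 2 `C[C@@H]1O[C@H](C2CCCCC2)C([Si](C)(C)C)=C(Cl)[C@H]1C` gives 38000 nM in this assay.

Among the measured compounds shown here, only two compounds have numbers so far, and compound 2 holds the higher of them, yet its gap to compound 1 is small: the step of a 1.2-fold higher number from compound 1 to compound 2 (0.07 log units; within the scatter) stays within the scatter, so the two cannot be told apart on this read-out. For the measured compounds named here, that step, methyl in place of hydrogen on a saturated ring carbon, is the only measured change available, and it does not touch the part of the molecule that is altered next.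

Compound 3 `C[C@@H]1O[C@H](CCC=C(Br)Br)C([Si](C)(C)C)=C(Cl)[C@H]1C` carries 4,4-dibromobut-3-en-1-yl in place of cyclohexyl on a saturated ring carbon. Going by the values given here, no measured step involves this position or these groups, so nothing in the data points to a direction; what remains is that both measured compounds sit in the same weak range. The most defensible expectation is therefore a number near that of compound 2, with a wide margin of uncertainty in both directions, and the step of a 1.3-fold lower number from compound 2 to compound 3 (0.10 log units; within the scatter) is expected to be modest. Compound 3 is estimated at 30000 nM, within a range from 7000 nM to 120000 nM.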

Compound 3, concentration for total growth inhibition: 33000 nM
Estimate against measurement, compound 3: 1.1-fold (0.04 log units) below; low and high end bracket the measured number.
By their numbers in this assay, from the lowest: compounds 1, 3 and 2 (each within the scatter of the next).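

Putting a 4,4-dibromobut-3-en-1-yl chain in place of cyclohexyl, on the saturated ring carbon next to the ring oxygen, gives a 1.2-fold lower number from compound 2 to compound 3 (0.06 log units; within the scatter) in this assay, so the two compounds cannot be told apart on this read-out. Among the compounds shown here, this is the first measured change at this position, and it shows that, for this pair, the six-membered carbon ring can give way to an open chain with a double bond and the growth-inhibition number stays in the same weak range. Both groups have 6 heavy atoms, though the chain's are 4 carbon and 2 bromine, and no further evidence bears on this result.

Neither group has a hydrogen-bond donor or acceptor, so the compounds shown leave open whether an amine or a carboxylic acid on this carbon would move the number beyond the scatter. Also open, from the compounds shown here alone, is what a longer chain or a phenyl ring in this place would do, and whether any such group could bring the number far below the weak range seen here.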